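This account rests on a few compounds, and the source may have more. Where it says the series, first, only, none or still open, it means among the compounds named here.

Measured in a functional assay on HCT-116 cells (Homo sapiens) for antiproliferative activity, read by MTT assay, with a stated time of 48 h; on this read-out higher numbers stand for weaker inhibition and lower numbers for stronger inhibition:
- compound 1 `CC(CCO)n1cnc2c(Cl)nc(F)nc21`: 19800 nM
- compound 2 `CCC(CCO)n1cnc2c(Cl)nc(F)nc21`: 18900 nM
- compound 3 `CCC(CCO)n1cnc2c(Cl)ncnc21`: > 50000 nM (a limit, not a number)

Compound 2 at 18900 nM lies within the scatter of compound 1 at 19800 nM. The remaining result is the limit for compound 3, noted as the limit of > 50000 nM in this assay, at which 1 of the 3 values shown sits.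

Next is compound 4 `CCCC(CCO)n1cnc2c(Cl)nc(F)nc21`, which differs from compound 2 by methyl in place of hydrogen on a saturated chain carbon, three bonds along the chain from an aromatic nitrogen, or ethyl to propyl.

The closest measured change is methyl in place of hydrogen on a saturated chain carbon, two bonds along the chain from an aromatic nitrogen, which gave a 1.0-fold lower number from compound 1 to compound 2 (0.02 log units; within the scatter). The other measured change, an at least 2.6-fold higher number from compound 2 to compound 3 (0.42 log units; beyond the scatter), replaces fluoro with hydrogen on an aromatic carbon. It is a different kind of change and offers no direct guide here.

In this assay, no shift beyond the scatter is therefore expected, with the expected step being a 1.1-fold lower number from compound 2 to compound 4 (0.05 log units; within the scatter). For compound 4 the estimated value is 17000 nM, with an expected range of 8500 nM to 36000 nM.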

Compound 4, half-maximal inhibitory concentration: 16500 nM
For compound 4 the middle estimate is 1.0-fold (0.01 log units) above the measured one, and the stated range covers the measured number.
By their numbers in this assay, from the lowest: compounds 4, 2 and 1 (each within the scatter of the next). At a limit, above all of these: compound 3.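

Methyl in place of hydrogen on a saturated chain carbon, three bonds along the chain from an aromatic nitrogen, gives a 1.1-fold lower number from compound 2 to compound 4 (0.06 log units; within the scatter) in this assay and shows that the flat response seen at the earlier chain step continues one carbon further out. The whole extension gives a 1.2-fold lower number from compound 1 to compound 4 (0.08 log units; within the scatter) as well, so compound 1, compound 2 and compound 4 stand at one level across these chain lengths. Nothing on hand gives a reason for this flat response.

Going by these compounds, whether the level holds for a longer chain such as butyl or pentyl, or for a chain ending in an amine or a carboxylic acid instead of the hydroxyl, stays open. On these data alone, how propyl behaves with hydrogen in place of fluoro also stays open.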